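A few compounds are considered here, and "the series" means these few. Any claim that something is new, unique, unknown or untested is made for them only; others in the source may bear on it.

Measured so far:
Compound 1 `COc1cc(-c2nccn2C)cc(OC)c1OC`: > 100000 nM
Compound 2 `CCn1ccnc1-c1cc(OC)c(OC)c(OC)c1`: > 100000 nM
Compound 3 `CCCCn1ccnc1-c1cc(OC)c(OC)c(OC)c1`: > 100000 nM

In a functional assay on T47D cells (Homo sapiens) for antiproliferative activity, read by MTT assay, with a stated time of 72 h (on this read-out higher numbers stand for weaker inhibition and lower numbers for stronger inhibition), compound 2 gives > 100000 nM, which is a limit of the assay and not a number. Compound 1 gives > 100000 nM, again a limit. Compound 3 gives > 100000 nM, also a limit. Among the compounds with values here, the series so far therefore consists of the limit of > 100000 nM in this assay, at which 3 of the 3 values shown sit, and compound 2 has no measured number to set it apart from the others.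

The next compound is compound 4 `COc1cc(-c2nccn2CC(C)C)cc(OC)c1OC`. The change from compound 2 is isopropyl in place of methyl on a saturated chain carbon bound to an aromatic nitrogen, which cut one bond further out reads ethyl to isobutyl.

Three measured steps alter this same chain: a step that the two limits leave unreadable from compound 1 to compound 2, a step that the two limits leave unreadable from compound 1 to compound 3 and a step that the two limits leave unreadable from compound 2 to compound 3. None of them gives a size that could be carried over, and none gives a direction. The expectation therefore rests on all three chains ending at the same limit, and no change beyond the scatter is expected. The expected step that the limit leaves unreadable from compound 2 to compound 4 is accordingly small and has no firm direction. Compound 4 is estimated at 150000 nM, with an expected range of 60000 nM to 400000 nM, and will most probably be reported as a limit again.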

Compound 4, half-maximal inhibitory concentration: > 100000 nM
Compound 4 was reported as a limit; the forecaster's own chance of this, stated with the estimate: 90%; the middle value lies beyond the limit too.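

Within the data shown here, no new step can be read from compound 4: in this assay its result is a limit, as are those of compound 1, compound 2 and compound 3, so no step among them has a size or a direction. All four compounds share one result: the limit of > 100000 nM in this assay, at which 4 of the 4 values shown sit.

The compounds shown leave open whether changing the chain alters activity at all, and how far each compound lies beyond the limit.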